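Removing One Methyl from the Amide of Compound 2

The source may hold more compounds than are shown below. What is called first, only, known or untested is meant among the compounds shown, and "the series" means these compounds.

In an in vitro ADME assay on microsomes from liver (Homo sapiens) for metabolic stability (on this read-out higher numbers stand for fast clearance and lower numbers for slow clearance), two compounds sharing one core have been measured so far. Compound 1 (`CC[C@H](C)[C@@H]1C(=O)N[C@H](C2Cc3ccccc3C2)C(=O)N1[C@@H](C(=O)N(C)C)c1ccc(C)[n+]([O-])c1`) gives 1 mL.min-1.g-1, and compound 2 (`CC[C@H](C)[C@@H]1C(=O)N[C@H](C2Cc3ccccc3C2)C(=O)N1[C@@H](C(=O)N(C)C)c1cnc(C)cc1C`) gives 9 mL.min-1.g-1, the higher of the two numbers.

The next compound, compound 3 (`CC[C@H](C)[C@@H]1C(=O)N[C@H](C2Cc3ccccc3C2)C(=O)N1[C@@H](C(=O)NC)c1cnc(C)cc1C`), differs from compound 2 in one place: hydrogen in place of methyl on an amide-type nitrogen. Dimethylcarbamoyl thus becomes methylcarbamoyl, with hydrogen in place of methyl on an amide-type nitrogen.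

Among the compounds with values here, only one measured step is available, a 9.0-fold higher number from compound 1 to compound 2 (0.95 log units; beyond the scatter). It lies beyond the scatter, but it exchanges the group carrying the six-membered aromatic ring and leaves this nitrogen untouched. It therefore shows how far the numbers have moved within this pair, and it gives no direct measure of the change at hand. Within the data shown here, no measured step involves the amide-type nitrogen, so only a small change is expected in this assay, leaning towards a lower number and possibly not beyond the scatter.

The expected change is a 1.5-fold lower number from compound 2 to compound 3 (0.18 log units; within the scatter). For compound 3 the estimated value is 6 mL.min-1.g-1, with an expected range from 2.5 mL.min-1.g-1 to 13 mL.min-1.g-1.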

Compound 3, intrinsic clearance in microsomes: 7 mL.min-1.g-1
For compound 3 the middle estimate is 1.2-fold (0.07 log units) below the measured one, within the range that was stated.
By their numbers in this assay, from the lowest: compound 1; then compounds 3 and 2 (each within the scatter of the next).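

In this assay, the amide-type nitrogen now has a measured step of its own: hydrogen in place of methyl, which turns dimethylcarbamoyl into methylcarbamoyl, gives a 1.3-fold lower number from compound 2 to compound 3 (0.11 log units; within the scatter), and this lies within the scatter. With the rest of compound 2 held constant, the read-out therefore does not separate the methyl from the hydrogen at this position, whereas the exchange of the group carrying the six-membered aromatic ring gave a 9.0-fold higher number from compound 1 to compound 2 (0.95 log units; beyond the scatter), a step beyond the scatter. Nothing measured here offers an explanation for this result.

The compounds shown cover only methyl and hydrogen on this nitrogen, so it remains open how the read-out would respond to an ethyl group, a longer chain or a chain ending in an amine or a carboxylic acid. Within the data shown here, it also remains open whether hydrogen in place of methyl on this nitrogen would read the same way when the aromatic group of compound 1 is present, since the one step at this position was taken from compound 2.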